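The compounds below may be only part of what the source reports. "The series", "measured", "known", "first", "only" and "open" are said of these compounds alone.

Measured compounds in this series:
- compound 2 `Cc1cnn(-c2ccc(C)nc2C(=O)N2CC3(CC3)C[C@H]2CNc2ccc(C(F)(F)F)cn2)c1` — 8.3
- compound 3 `Cc1cccc(NC[C@@H]2CC3(CC3)CN2C(=O)c2nc(C)sc2-c2ccccc2)n1` — 7.6
- compound 1 `Cc1nc(C(=O)N2CCC3(CC3)C[C@H]2CNc2ccc(Cl)cn2)c(-c2ccccc2)s1` — < 5 (a limit of the assay, not a number)

In a functional assay on HEK293 cells for antagonist activity at Orexin receptor type 2 (Homo sapiens), read by FLIPR and calcium flux (on this read-out higher numbers stand for higher potency (the scale is a negative logarithm) and lower numbers for lower potency), compound 2 gives 8.3, the higher of the two numbers available. Compound 3 gives 7.6, lower by a margin beyond the usual scatter. Compound 1 reaches a limit of the assay, < 5; this is the limit of < 5 in this assay, at which 1 of the 3 values shown sits.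

Compound 4 `Cc1ccc(OCc2ccccc2)c(C(=O)N2CC3(CC3)C[C@H]2CNc2ccc(C(F)(F)F)cn2)n1` has not yet been measured in this assay. It differs from compound 2 in one place: benzyloxy in place of 4-methyl-1H-pyrazol-1-yl on an aromatic carbon. Within the data shown here, no measured pair shows this change, so its size is uncertain. A modest downward step, a number 0.80 log units lower from compound 2 to compound 4 (beyond the scatter), is expected. Compound 4 is estimated at 7.5, within 6.5 to 8.5.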

Compound 4, negative logarithm of the antagonist equilibrium constant: 8.6
The estimate for compound 4 lay 1.10 log units below the measured number, outside the stated range (above it).
By their numbers in this assay, from the lowest: compound 3; then compounds 2 and 4 (each within the scatter of the next). At a limit, below all of these: compound 1.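

In this assay, benzyloxy in place of 4-methyl-1H-pyrazol-1-yl on this aromatic carbon gives a number 0.30 log units higher from compound 2 to compound 4 (within the scatter) as the step for the change. This position, ortho to a large group, therefore accepts a six-membered aromatic ring of carbon only, carried as benzyloxy, as well as a five-membered aromatic ring with 2 hetero atoms, with the two compounds within the scatter of each other. Nothing measured here bears on why the two groups read alike.

Open, going by these compounds, is whether a methoxy group, an amine or a carboxylic acid on this carbon would keep the number. Also open, on these data alone, is whether benzyloxy holds up with a pyridine other than the trifluoromethyl one on the side chain.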